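The source may report more compounds than this note shows. Statements on the series, on what has been measured and on what is new or still open speak of the compounds shown alone.

In a functional assay on aorta (Rattus norvegicus, strain Sprague-Dawley) for inhibition (a higher number here means that more compound is needed for the effect, a lower number that less compound is needed), compound 1 `CCCCCCOc1cc2c(c3c1C[C@@H]1[C@@H](C)CO[C@]1(C)O3)C[C@@H]1[C@@H](C)CO[C@]1(C)O2` gives > 200000 nM, which is a limit of the assay and not a number. Compound 3 `C[C@H]1CO[C@]2(C)Oc3cc(OC/C=C/c4ccccc4)c4c(c3C[C@H]12)O[C@@]1(C)OC[C@H](C)[C@H]1C4` gives > 200000 nM, also a limit. Compound 1 therefore stands at the limit of > 200000 nM in this assay, at which 2 of the 3 values shown sit. Compound 2 `COc1cc2c(c3c1C[C@@H]1[C@@H](C)CO[C@]1(C)O3)C[C@@H]1[C@@H](C)CO[C@]1(C)O2`, with hydrogen in place of pentyl, gives 33000 nM. Compound 4 `CCCCOc1cc2c(c3c1C[C@@H]1[C@@H](C)CO[C@]1(C)O3)C[C@@H]1[C@@H](C)CO[C@]1(C)O2` makes a smaller cut to the chain of compound 1: hydrogen in place of ethyl on a saturated chain carbon, four bonds along the chain from an oxygen on an aromatic ring. The nearest guide is an at least 6.0-fold lower number from compound 1 to compound 2 (0.78 log units; beyond the scatter), a step that removes more of the same chain, and an at least 6.0-fold higher number from compound 2 to compound 3 (0.78 log units; beyond the scatter) also bears on it. Only part of the first step is therefore expected in this assay, towards a lower number. The estimated change is an at least 2.2-fold lower number from compound 1 to compound 4 (0.34 log units; beyond the scatter). Compound 4 is expected at 90000 nM, with an estimated range of 35000 nM to 200000 nM.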

Compound 4, half-maximal effective concentration: > 200000 nM
Compound 4 ended at the assay's limit; the forecaster's own chance of this, stated with the estimate: 35%; middle value at least 2.2-fold (0.34 log units) from the limit.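

Propyl in place of hydrogen on a saturated chain carbon bound to an oxygen on an aromatic ring gives an at least 6.0-fold higher number from compound 2 to compound 4 (0.78 log units; beyond the scatter), so the shorter chain of compound 4 does not bring back the lower number of compound 2. In this assay compound 4 stands at a limit, not a number: the limit of > 200000 nM in this assay, at which 3 of the 4 values shown sit. The steps from compound 1 and compound 3 to compound 4 join two limits and cannot be read.

Where the number starts to climb between compound 2 and compound 4 remains open, and an ethyl chain would narrow this down. As far as these compounds go, whether a chain ending in an amine behaves the same way also remains open.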